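Exchanging the aryl group on the ring nitrogen

The source may hold more compounds than are shown below. What is called first, only, known or untested is meant among the compounds shown, and "the series" means these compounds.

Two compounds of the shared core have been run in a functional assay on A549 cells (Homo sapiens) for cytotoxicity, read by MTT assay, with a stated time of 72 h; on this read-out higher numbers stand for weaker inhibition and lower numbers for stronger inhibition. Compound 1 `Cc1cc(=O)n(-c2ccccc2OC(F)(F)F)nc1C(=O)Nc1ccc(Oc2ncnc3[nH]ccc23)cc1` gives 16200 nM. Compound 2 `Cc1cc(=O)n(-c2cccc(F)c2)nc1C(=O)Nc1ccc(Oc2ncnc3[nH]ccc23)c(F)c1` gives 31500 nM, the higher of the two numbers shown, but its gap to compound 1 lies within the scatter and so carries no ranking. Compound 3 `Cc1cc(=O)n(-c2ccccc2OC(F)(F)F)nc1C(=O)Nc1ccc(Oc2ncnc3[nH]ccc23)c(F)c1` is not yet measured. It differs from compound 2 in one place: 2-(trifluoromethoxy)phenyl in place of 3-fluorophenyl on an aromatic nitrogen. Within the data shown here, no measured pair isolates this exchange; compound 1 carries the same 2-(trifluoromethoxy)phenyl group but lacks the fluorine that compound 2 and compound 3 share. In this assay the step from compound 2 to compound 3 is expected to be small, toward a lower number, and not beyond the scatter, leaning on compound 1 at 16200 nM. Compound 3 is therefore estimated at 20000 nM, with a range from 8000 nM to 50000 nM, an expected step of a 1.6-fold lower number from compound 2 to compound 3 (0.20 log units; within the scatter).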

Compound 3, half-maximal inhibitory concentration: 16200 nM
Compound 3: middle estimate off by 1.2-fold (0.09 log units), on the high side, within the range that was stated.
By their numbers in this assay, from the lowest: compounds 1, 3 and 2 (each within the scatter of the next).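

In this assay, the pair that isolates the aryl exchange on the aromatic nitrogen gives a 1.9-fold lower number from compound 2 to compound 3 (0.29 log units; within the scatter), so 2-(trifluoromethoxy)phenyl and 3-fluorophenyl are not told apart at this position. The other pair now available, with fluoro in place of hydrogen on an aromatic carbon, gives no change at the digits printed from compound 1 to compound 3 (within the scatter), so this second change does not separate its two compounds either. Nothing at hand bears on the reason for either result.

Still open, from the compounds shown here alone, is whether a different kind of group on the aromatic nitrogen, such as a phenyl carrying an amine or a carboxylic acid, or a longer alkyl chain in place of the aryl ring, would separate from these compounds in this assay. Also open, going by these compounds, is whether any exchange at this position produces a step beyond the scatter.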